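A few compounds are considered here, and "the series" means these few. Any claim that something is new, unique, unknown or untested is made for them only; others in the source may bear on it.

Measured so far in an assay on isolated protein (Aquatica lateralis) for inhibition of Luciferin 4-monooxygenase (Luciola lateralis), read by a luciferase reporter; a lower number here means a stronger inhibitor, a higher number a weaker inhibitor: compound 1 `O=C(Nc1ccc(-c2ccccc2)cn1)c1ccccc1` gives 69 nM. Compound 2 `O=C(Nc1ccc(-c2ccc(Cl)cc2)cn1)c1ccccc1` gives 560 nM. Compound 3 `COc1ccc(-c2ccc(NC(=O)c3ccccc3)nc2)cc1` gives 310 nM.

Compound 1 gives the lowest number of the three, and both steps away from it lie beyond the scatter: an 8.1-fold higher number from compound 1 to compound 2 (0.91 log units; beyond the scatter) and a 4.5-fold higher number from compound 1 to compound 3 (0.65 log units; beyond the scatter). Compound 2 and compound 3 sit close together, a 1.8-fold lower number from compound 2 to compound 3 (0.26 log units; within the scatter). Compound 4 `Nc1ccc(C(=O)Nc2ccc(-c3ccccc3)cn2)cc1` differs from compound 1 by amino in place of hydrogen on an aromatic carbon. Among the measured compounds shown here, no measured step adds an amino group or alters this part of the shared core, so the two measured steps bear on it only by analogy; both of them made the number higher by a modest amount. On that basis a small rise, not a large one, is expected, a 1.9-fold higher number from compound 1 to compound 4 (0.28 log units; within the scatter). Compound 4 is estimated at 130 nM, with a range from 40 nM to 450 nM.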

Compound 4, half-maximal inhibitory concentration: 1200 nM
The estimate for compound 4 lay 9.2-fold (0.97 log units) below the measured number, outside the stated range (above it).
By their numbers in this assay, from the lowest: compound 1; then compounds 3 and 2 (each within the scatter of the next); then compound 4.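

Amino in place of hydrogen, para to a large group, is the first change shown at this part of the shared core, and it gives a 17-fold higher number from compound 1 to compound 4 (1.24 log units; beyond the scatter). This step is large, whereas the chloro and methoxy steps elsewhere on compound 1 were modest, so this position is sensitive to at least this substitution. No measurement shown accounts for the size of the step.

Still open, going by these compounds, is whether a hydroxyl, a dimethylamino group or a carboxylic acid at the same place would behave like amino. Also open, on these data alone, is whether amino elsewhere on this ring would give a comparable rise.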